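Compound 4: from methyl to fluoro on the ring

The source may report more compounds than this note shows. Statements on the series, on what has been measured and on what is new or still open speak of the compounds shown alone.

In a functional assay (aorta) with Oryctolagus cuniculus as the target (a lower number here means a stronger inhibitor, a higher number a weaker inhibitor), the measured compounds are
compound 1 `CC1=C(C)C(=O)C(C(CCCCCCC(=O)O)c2ccccc2)=C(C)C1=O` with 3200 nM
compound 2 `CC1=C(C)C(=O)C(C(CCCCCCCC(=O)O)c2ccccc2)=C(C)C1=O` with 3400 nM
compound 3 `CC1=C(C)C(=O)C(C(CCCCCC(=O)O)c2ccc(C)cc2)=C(C)C1=O` with 1000 nM

Of these three, compound 3 at 1000 nM has the lowest number, so it is the strongest inhibitor here, and its gaps to compound 1 and compound 2 both lie beyond the scatter. Compound 4 `CC1=C(C)C(=O)C(C(CCCCCC(=O)O)c2ccc(F)cc2)=C(C)C1=O` has not yet been measured. It keeps the chain of compound 3 and changes one group. The change is fluoro in place of methyl on an aromatic carbon and in words it is fluoro in place of methyl on an aromatic carbon, so 4-methylphenyl becomes 4-fluorophenyl.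

Going by the values given here, the only measured step, a 1.1-fold higher number from compound 1 to compound 2 (0.03 log units; within the scatter) and thus within the scatter, lies in the chain and not on the ring, so it is no direct guide to this swap. Compound 3 differs from compound 1 in more than one place, so their gap cannot be pinned on the methyl alone. Among the compounds with values here, no measured compound carries fluoro. Compound 1 at 3200 nM has no group on that aromatic carbon, so a drift toward its value seems likelier than a further drop. A small upward step is expected, a 1.5-fold higher number from compound 3 to compound 4 (0.18 log units; within the scatter) with much uncertainty. The estimated value for compound 4 is 1500 nM with an expected range from 600 nM to 3800 nM in repeat measurements.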

Compound 4, half-maximal inhibitory concentration: 48 nM
The estimate for compound 4 lay 31-fold (1.49 log units) above the measured number, and the stated range ends above it.
By their numbers in this assay, from the lowest: compound 4; then compound 3; then compounds 1 and 2 (each within the scatter of the next).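

In this assay the change from 4-methylphenyl to 4-fluorophenyl gives a 21-fold lower number from compound 3 to compound 4 (1.32 log units; beyond the scatter) while the chain and the rest of the molecule stay the same. This shows that the group on this aromatic carbon can shift the number far beyond the scatter, even when only one heavy atom is exchanged for another. Going by these compounds alone, the earlier compounds could not show this, since their only readable step lay in the chain and stayed within the scatter, and no earlier compound differed from another at this ring position alone. Nothing available here accounts for the size of this effect.

From the compounds shown here alone, it remains open whether fluoro is unusual at this position or whether other small groups, such as chloro, methoxy or hydroxyl, would give similarly low numbers, and a plain hydrogen on this carbon with the chain of compound 4 would show what each group adds. Going by these compounds, it is also open whether fluoro would have a similar effect on the chains of compound 1 and compound 2.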